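This account rests on a few compounds, and the source may have more. Where it says the series, first, only, none or still open, it means among the compounds named here.

In a functional assay on K562 cells (Homo sapiens) for cytotoxicity, read by trypan blue exclusion, with a stated time of 96 h (on this read-out lower numbers stand for stronger inhibition and higher numbers for weaker inhibition), compound 1 `COc1ccc(NS(=O)(=O)/C=C/c2c(OC)cc(OC)cc2OC)cc1` gives 75 nM and compound 2 `COC(=O)C(C)(C)Nc1cc(NS(=O)(=O)/C=C/c2c(OC)cc(OC)cc2OC)ccc1OC` gives 300 nM. Compound 3 `COC(=O)C(Nc1cc(NS(=O)(=O)/C=C/c2c(OC)cc(OC)cc2OC)ccc1OC)c1ccc(Cl)cc1` gives 2500 nM, the highest of the three numbers, so it is the weakest inhibitor measured so far. Compound 4 `COc1cc(OC)c(/C=C/S(=O)(=O)Nc2ccc(OC)c(NC(C(=O)O)c3ccccc3)c2)c(OC)c1` differs from it on a nitrogen on an aromatic ring, where carboxy(phenyl)methyl stands in place of (4-chlorophenyl)(methoxycarbonyl)methyl (carboxy(phenyl)methyl in place of (4-chlorophenyl)(methoxycarbonyl)methyl on a nitrogen on an aromatic ring).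

Going by the values given here, two measured steps bear on this change, although neither makes the same swap. Putting the (1-(methoxycarbonyl)-1-methylethyl)amino group in place of hydrogen gave a modest rise (a 4.0-fold higher number from compound 1 to compound 2 (0.60 log units; beyond the scatter)). Changing the group on the nitrogen, the closer precedent, gave another modest rise (an 8.3-fold higher number from compound 2 to compound 3 (0.92 log units; beyond the scatter)). Among the compounds with values here, both moved the number upward, but no measured pair shows what this particular swap does, so the direction remains uncertain. A small upward move is expected, no larger than those modest steps (a 1.4-fold higher number from compound 3 to compound 4 (0.15 log units; within the scatter)). Compound 4 is therefore expected near 3500 nM (estimated range 700 nM to 18000 nM).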

Compound 4, half-maximal inhibitory concentration: 300 nM
Estimate against measurement, compound 4: 12-fold (1.07 log units) above; the measured number lies below the stated range.
By their numbers in this assay, from the lowest: compound 1; then compounds 2 and 4 (each within the scatter of the next); then compound 3.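

The lower number for the carboxy(phenyl)methyl group (an 8.3-fold lower number from compound 3 to compound 4 (0.92 log units; beyond the scatter)) shows that the number at this nitrogen can fall as well as rise, which the two earlier steps, both upward, did not show. The group also reads level with 1-(methoxycarbonyl)-1-methylethyl (no change at the digits printed from compound 2 to compound 4 (within the scatter)), yet the number stays above that of the unsubstituted compound (a 4.0-fold higher number from compound 1 to compound 4 (0.60 log units; beyond the scatter)), so in these compounds no group on this nitrogen matches having none there. No measurement here explains these differences.

This swap removes the chlorine and replaces the methoxycarbonyl with carboxy at once, and the compounds shown do not separate the two changes. From the compounds shown here alone, a phenyl(methoxycarbonyl)methyl group on this nitrogen would separate them, and how a carboxamide in place of the carboxy would read remains open too.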